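A few compounds are considered here, and "the series" means these few. Any claim that something is new, unique, unknown or untested is made for them only; others in the source may bear on it.

Of the compounds shown here, three built on one shared core have so far been tested in a functional assay on the whole organism with Rattus norvegicus as the target; on this read-out lower numbers stand for an effect already at smaller amounts and higher numbers for an effect only at larger amounts of compound. Compound 1, `Cc1cccc(NN=C2CCC(C)n3c2ncc(C(=O)O)c3=O)c1C`, gives in this assay > 100 umol/kg, which is a limit of the assay rather than a number. Compound 2, `Cc1ccc(NN=C2CCC(C)n3c2ncc(C(=O)O)c3=O)cc1C`, gives in this assay > 100 umol/kg, again a limit and not a number. Compound 3, `Cc1cc(C)c(NN=C2CCC(C)n3c2ncc(C(=O)O)c3=O)cc1C`, gives in this assay 320 umol/kg. The step that the two limits leave unreadable from compound 1 to compound 2 and the step that the limit leaves unreadable from compound 2 to compound 3 cannot be sized, because the limit of > 100 umol/kg in this assay, at which 2 of the 3 values shown sit, hides where two of the three compounds actually lie. Among the compounds with values here, compound 2 therefore stands at a limit, with one other compound at the same limit and compound 3 the only one with a number. Compound 4, `CC1CCC(=NNc2ccc(Cl)cc2Cl)c2ncc(C(=O)O)c(=O)n21`, is not yet measured. It differs from compound 2 in one place: 2,4-dichlorophenyl in place of 3,4-dimethylphenyl on an amine nitrogen. Within the data shown here, no measured step covers a change of this kind, and the two steps that exist are unreadable, so no size or direction can be drawn from them; the expectation rests only on the level of the three measured compounds. Compound 4 is expected to give 200 umol/kg, between 50 umol/kg and 1000 umol/kg. This amounts to an expected step that the limit leaves unreadable from compound 2 to compound 4.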

Compound 4, dose for 50% inhibition: > 100 umol/kg
Compound 4: only a limit was reported; the forecaster's own chance of this, stated with the estimate: 50%; the middle value lies beyond the limit too.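

No new step can be read from compound 1 or compound 2 to compound 4 in this assay, because all three compounds give a limit rather than a number: the limit of > 100 umol/kg in this assay, at which 3 of the 4 values shown sit.

Where these three compounds actually lie, and whether 2,4-dichlorophenyl in place of 3,4-dimethylphenyl changes the effect at all, stays open.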